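A cyclopropyl swap on a sulfonamide at the assay limit

A few compounds are considered here, and "the series" means these few. Any claim that something is new, unique, unknown or untested is made for them only; others in the source may bear on it.

Compound 1 `COc1ccc(-c2cc(-c3cccc(S(C)(=O)=O)c3)cnc2N)cn1`: > 100 ug/mL
Compound 2 `COc1ccc(-c2cc(-c3ccc(S(=O)(=O)N(C)C)cc3)cnc2N)cn1`: > 100 ug/mL
Compound 3 `CNS(=O)(=O)c1ccc(-c2cnc(N)c(-c3ccc(OC)nc3)c2)cc1`: > 100 ug/mL

Each of these readings is a limit of the assay and not a number. In a physicochemical assay for solubility, read by nephelometry, measured as kinetic solubility, at pH 2 (a lower number here means a less soluble compound, a higher number a more soluble compound), compound 3 stands only at a limit, > 100 ug/mL. The measured compounds all share one reading, (the limit of > 100 ug/mL in this assay, at which 3 of the 3 values shown sit).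

Compound 4 `COc1ccc(-c2cc(-c3ccc(S(=O)(=O)NC4CC4)cc3)cnc2N)cn1` has cyclopropyl in place of methyl on a sulfonamide nitrogen, compared with compound 3: cyclopropyl in place of methyl on a sulfonamide nitrogen.

For the measured compounds named here, one measured step bears on this, since it changes the same nitrogen: a step that the two limits leave unreadable from compound 2 to compound 3. Going by the values given here, with a step that the two limits leave unreadable from compound 2 to compound 3 as the only measured change there, no size can be carried over, so no step beyond the usual scatter is expected in this assay, in either direction. The estimated step is a step that the limit leaves unreadable from compound 3 to compound 4. Compound 4 is estimated at 110 ug/mL, with an expected range of 50 ug/mL to 200 ug/mL, and it may well return only a limit again.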

Compound 4, solubility: > 100 ug/mL
Compound 4 ended at the assay's limit (the forecaster's own chance of this, stated with the estimate: 75%); the middle value is on the limit's open side.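

No step can be read among compound 2, compound 3 and compound 4, since each reading is only a limit of the assay: the limit of > 100 ug/mL in this assay, at which 4 of the 4 values shown sit.

As far as these compounds go, whether cyclopropyl in place of methyl on the sulfonamide nitrogen changes anything in this assay stays open, as does how the four compounds truly compare.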